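The source may report more compounds than this note shows. Statements on the series, on what has been measured and on what is new or still open speak of the compounds shown alone.

Compounds 1, 2 and 3 share one core and differ only in the group carried on a single aromatic carbon. Compound 1 `CC(C)(C)[Si](C)(C)OC[C@H]1O[C@@H](n2cnc3c(N)ncnc32)[C@H](O[Si](C)(C)C(C)(C)C)[C@]12OS(=O)(=O)C=C2N` bears amino there, compound 2 `CN(C)c1ncnc2c1ncn2[C@@H]1O[C@H](CO[Si](C)(C)C(C)(C)C)[C@@]2(OS(=O)(=O)C=C2N)[C@H]1O[Si](C)(C)C(C)(C)C` dimethylamino, and compound 3 `CC(C)(C)[Si](C)(C)OC[C@H]1O[C@@H](n2cnc3cncnc32)[C@H](O[Si](C)(C)C(C)(C)C)[C@]12OS(=O)(=O)C=C2N` hydrogen. In a functional assay on MT4 cells (Homo sapiens) for cytotoxicity (a lower number here means that less compound is tolerated, a higher number that more compound is tolerated), compound 1 gives 13000 nM, compound 2 gives 15000 nM, and compound 3 gives 13000 nM. Compound 2 thus sits within the scatter of both others: a 1.2-fold higher number from compound 1 to compound 2 (0.06 log units; within the scatter), and a 1.2-fold lower number from compound 2 to compound 3 (0.06 log units; within the scatter); between the other two, no change at the digits printed from compound 1 to compound 3 (within the scatter).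

Compound 4 `CCn1cnc2ncn([C@@H]3O[C@H](CO[Si](C)(C)C(C)(C)C)[C@@]4(OS(=O)(=O)C=C4N)[C@H]3O[Si](C)(C)C(C)(C)C)c2c1=O` differs from compound 2 in a larger way: a group of 12 heavy atoms (7 carbon, 4 nitrogen, 1 oxygen; one five-membered aromatic ring with 2 hetero atoms, one six-membered aromatic ring with 2 hetero atoms) in place of a group of 12 heavy atoms (7 carbon, 5 nitrogen; one five-membered aromatic ring with 2 hetero atoms, one six-membered aromatic ring with 2 hetero atoms), on a saturated ring carbon. The three measured steps bear on this only loosely, since each of them exchanged one small group on the aromatic part, and all stayed within the scatter; none exchanged the whole group. The step from compound 2 to compound 4 is therefore expected to be a 1.1-fold lower number from compound 2 to compound 4 (0.03 log units; within the scatter), none beyond the scatter. On that basis the estimate for compound 4 in this assay is 14000 nM, with an expected range from 7000 nM to 28000 nM.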

Compound 4, half-maximal cytotoxic concentration: > 150000 nM
Compound 4: no number, only a limit; the forecaster's own chance of this, stated with the estimate: 10%; at least 10-fold (1.02 log units) between middle value and limit.
By their numbers in this assay, from the lowest: compounds 1, 3 and 2 (each within the scatter of the next). At a limit, above all of these: compound 4.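

Compound 4 gives only a limit in this assay, not a number: the limit of > 150000 nM in this assay, at which 1 of the 4 values shown sits. Exchanging the whole group on the saturated ring carbon next to the ring oxygen moves the read-out beyond the scatter (an at least 10-fold higher number from compound 2 to compound 4 (1.00 log units; beyond the scatter)) and likewise against the other two compounds (an at least 11-fold higher number from compound 3 to compound 4 (1.06 log units; beyond the scatter); an at least 11-fold higher number from compound 1 to compound 4 (1.06 log units; beyond the scatter)), which the small exchanges on the aromatic carbon did not do. The group leaving compound 2 and the group entering compound 4 have the same count of heavy atoms and of hydrogen-bond acceptors, so these counts do not separate them, while the entering group holds 1 oxygen and 1 double bond outside aromatic rings.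

The compounds shown do not tell how far compound 4 lies past its limit. Nor do they tell whether the step follows the ring carbonyl or the ethyl chain, or what a methyl or propyl chain in place of that ethyl would give.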